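Ester variation on the shared core: cytotoxicity notes

The source may report more compounds than this note shows. Statements on the series, on what has been measured and on what is new or still open speak of the compounds shown alone.

Compound 3 `CC(C)OC(=O)C(O)Cn1cnc2c(N)ncnc21` sits at the assay limit in a functional assay on Vero cells (Chlorocebus sabaeus) for cytotoxicity (on this read-out lower numbers stand for higher toxicity in this test and higher numbers for lower toxicity in this test), giving > 400 ug/mL. Compound 1 `Nc1ncnc2c1ncn2CC(O)C(=O)OCCO` likewise reaches the limit, at > 400 ug/mL. Compound 2 `CCCCOC(=O)C(O)Cn1cnc2c(N)ncnc21` yields a number, 200 ug/mL. Two of the three values therefore rest at the limit of > 400 ug/mL in this assay, at which 2 of the 3 values shown sit. The step of an at least 2.0-fold lower number from compound 1 to compound 2 (0.30 log units; that floor lies within the scatter) and the step of an at least 2.0-fold higher number from compound 2 to compound 3 (0.30 log units; that floor lies within the scatter) each only reach the floor of the scatter, and a step that the two limits leave unreadable from compound 1 to compound 3.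

Compound 4 `COCCOC(=O)C(O)Cn1cnc2c(N)ncnc21` differs from compound 3 by 2-methoxyethyl in place of isopropyl on an oxygen next to a carbonyl group. The nearest measured comparison is the unreadable step that the two limits leave unreadable from compound 1 to compound 3, so no size can be read for this kind of change. The step of a number no higher from compound 3 to compound 4 (the limit leaves the size open) is expected to stay within the scatter. Compound 4 is expected to give 400 ug/mL, between 200 ug/mL and 800 ug/mL.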

Compound 4, minimum cytotoxic concentration: > 400 ug/mL
Compound 4: no number, only a limit; the forecaster's own chance of this, stated with the estimate: 70%; the middle value sits exactly at the limit.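

In this assay compound 4 gives > 400 ug/mL, a limit and not a number, so 2-methoxyethyl on this oxygen gives no number, as with isopropyl. Going by these compounds alone, the one readable step is an at least 2.0-fold higher number from compound 2 to compound 4 (0.30 log units; that floor lies within the scatter), and butyl remains the only ester here with a number. The steps to compound 4 from the other two esters cannot be read, as all three sit at one limit: the limit of > 400 ug/mL in this assay, at which 3 of the 4 values shown sit.

From the compounds shown here alone, how far these three esters lie past that limit stays open. Also open, going by these compounds, is whether a hexyl chain, or an amine at the end of the ester chain, would give a number.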